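Adding a Methyl to the Phenyl Ring of Compound 3

A few compounds are considered here, and "the series" means these few. Any claim that something is new, unique, unknown or untested is made for them only; others in the source may bear on it.

Compound 1 `COc1cc2c(Oc3ccc(NC(=O)c4cc(-c5ccccc5)ccn4)cc3F)ccnc2cc1OCCCN1CCN(C)CC1` is the starting point. In a functional assay on NCI-H460 cells (Homo sapiens) for cytotoxicity, read by MTT assay, with a stated time of 72 h (on this read-out lower numbers stand for stronger inhibition and higher numbers for weaker inhibition), compound 1 gives 91 nM. Compound 2 `COc1cc2c(Oc3ccc(NC(=O)c4cc(-c5ccccc5C)ccn4)cc3F)ccnc2cc1OCCCN1CCN(C)CC1` differs from it by one change, (methyl in place of hydrogen on an aromatic carbon), and in this assay compound 2 gives 150 nM. The step is a 1.6-fold higher number from compound 1 to compound 2 (0.22 log units; within the scatter). Compound 3 `COc1cc2c(Oc3ccc(NC(=O)c4cc(-c5ccccc5)ccn4)cc3F)ccnc2cc1OCCCN1CCCCC1` carries a different core; how the two cores differ is given by piperidin-1-yl in place of 4-methylpiperazin-1-yl on a saturated chain carbon, three bonds along the chain from an oxygen on an aromatic ring. In this assay compound 3 gives 120 nM.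

Compound 4 `COc1cc2c(Oc3ccc(NC(=O)c4cc(-c5ccc(C)cc5)ccn4)cc3F)ccnc2cc1OCCCN1CCCCC1` has not been measured. It arises from compound 3 by methyl in place of hydrogen on an aromatic carbon. Among the compounds with values here, this is the same kind of change as the one from compound 1 to compound 2, but the place is not the same: in compound 2 the methyl sits ortho to a large group, in compound 4 it sits para to a large group. Within the data shown here, only one such step has been measured, and on one core, so the expectation rests on that single step. The expected step is a 1.4-fold higher number from compound 3 to compound 4 (0.15 log units; within the scatter), and compound 4 is estimated at 170 nM, with a likely range from 85 nM to 340 nM.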

Compound 4, half-maximal inhibitory concentration: 160 nM
Compound 4: the middle estimate sits 1.1-fold (0.03 log units) above what was measured; low and high end bracket the measured number.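

In this assay, the methyl that turns the phenyl of compound 3 into the 4-methylphenyl of compound 4 gives a 1.3-fold higher number from compound 3 to compound 4 (0.12 log units; within the scatter), so this step cannot be told apart from the ordinary variation between repeated measurements. Set beside the earlier step, the same kind of change gives results that agree on the two cores: the same change on two cores in this assay, a 1.6-fold higher number (0.22 log units; within the scatter) from compound 1 to compound 2 and a 1.3-fold higher number (0.12 log units; within the scatter) from compound 3 to compound 4, 1.2-fold (0.09 log units) apart, within the scatter of two such steps. Within the data shown here, this shows only that neither core gives a clear shift with a methyl on this ring; it does not establish a rule for the series, as there are just two small steps and the methyl in compound 4 sits para to a large group, while the one in compound 2 sits at another place on the ring.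

The compounds shown leave open whether a 4-methylphenyl on the core of compound 1 would match the step seen here. They also leave open whether a different group at this place, such as a methoxy group, an amine or a carboxylic acid, would give a step beyond the scatter.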